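Working notes: from compound 2 to compound 3

This account rests on a few compounds, and the source may have more. Where it says the series, first, only, none or still open, it means among the compounds named here.

Values in a functional assay on HeLa cells (Homo sapiens) for antiproliferative activity, read by MTT assay, with a stated time of 48 h (a lower number here means a stronger inhibitor, a higher number a weaker inhibitor), for the measured compounds:
- compound 1 `COc1cc(CNC(=O)CCCCCCC(C)C)ccc1OC(=O)CCC(=O)Oc1ccc(-c2cc(=S)ss2)cc1` gives 5530 nM
- compound 2 `COc1cc(CNC(=O)CCCC/C=C/C(C)C)ccc1OC(=O)CCC(=O)Oc1ccc(-c2cc(=S)ss2)cc1` gives 4250 nM

On these two numbers, compound 2 cannot be separated from compound 1, so neither can be ranked above the other. Compound 3 `COc1cc(CNC(=O)CCCC/C=C/C(C)C)ccc1OC(=O)CCC(=O)Oc1ccc(C(N)=S)cc1` follows from compound 2 by a group of 3 heavy atoms (1 carbon, 1 nitrogen, 1 sulfur; no ring) in place of a group of 6 heavy atoms (3 carbon, 3 sulfur; one five-membered aromatic ring with 2 hetero atoms), on an aromatic carbon on an aromatic carbon of a six-membered aromatic ring of carbon only, para to a large group.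

Within the data shown here, the one measured step (a 1.3-fold lower number from compound 1 to compound 2 (0.11 log units; within the scatter)) exchanges isopentyl for 3-methylbut-1-en-1-yl. It does not touch the group changed here, so it gives no size for this change. Among the measured compounds shown here, no measured compound carries the entering group, and the expectation in this assay is therefore loose. The change removes the whole five-membered aromatic ring, so a real step is expected rather than none, although its direction is not settled by the data. A move toward a higher number is taken as the working expectation, and the estimate means a 2.1-fold higher number from compound 2 to compound 3 (0.33 log units; beyond the scatter) as the expected step. In this assay compound 3 is estimated at 9000 nM (range 3000 nM to 27000 nM).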

Compound 3, half-maximal inhibitory concentration: > 50000 nM
Compound 3 ended at the assay's limit; the forecaster's own chance of this, stated with the estimate: 10%; at least 5.5-fold (0.74 log units) between middle value and limit.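

In this assay, putting the group of no ring in place of the five-membered aromatic ring group, on an aromatic carbon para to a large group, gives an at least 11-fold higher number from compound 2 to compound 3 (1.07 log units; beyond the scatter), whereas the earlier chain change stayed within the scatter (a 1.3-fold lower number from compound 1 to compound 2 (0.11 log units; within the scatter)). With the chain and the rest of the core held fixed, this position is therefore the first place in the series where a single change separates two compounds, and the separation runs toward the weaker end of the assay. The value of compound 3, > 50000 nM, is a limit of this assay and not a number, so the full size of this step stays unknown: the limit of > 50000 nM in this assay, at which 1 of the 3 values shown sits.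

The compounds shown leave open which part of the five-membered aromatic ring group carries the difference, and whether any other group on the same aromatic carbon, such as an amine, a carboxylic acid or a nitrile, would stay near compound 2 or fall to the same limit. Also open, as far as these compounds go, is whether the isopentyl chain of compound 1 gives the same result when combined with the entering group.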